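Propyl to Vinyl on the Amine Chain

The source may hold more compounds than are shown below. What is called first, only, known or untested is meant among the compounds shown, and "the series" means these compounds.

Measured compounds:
Compound 1, `CCCCNc1nnc(SCC(=O)N(Cc2cccc([N+](=O)[O-])c2)c2ccc(F)cc2)s1`: 6.94%
Compound 2, `CCCNc1nnc(SCC(=O)N(Cc2cccc([N+](=O)[O-])c2)c2ccc(F)cc2)s1`: 8.5%

Both numbers come from an assay on isolated protein for inhibition of Amine oxidase [flavin-containing] A (Homo sapiens), read by fluorescence and Amplex Red, with a stated time of 30 min, tested at 0.01 nM; on this read-out higher numbers stand for a stronger effect at the one concentration tested and lower numbers for a weaker effect. Compound 1 stands lowest of the two, and its distance to compound 2 lies within the scatter. Compound 3, `C=CCNc1nnc(SCC(=O)N(Cc2cccc([N+](=O)[O-])c2)c2ccc(F)cc2)s1`, is not yet measured; against compound 1 it shows (vinyl in place of propyl on a saturated chain carbon bound to a nitrogen on an aromatic ring). Among the compounds with values here, the only measured step on this chain, a number 1.6 percentage points higher from compound 1 to compound 2 (within the scatter), also trims it and stayed within the scatter, so no change beyond the scatter is expected, a number 0.1 percentage points higher from compound 1 to compound 3 (within the scatter). Compound 3 is therefore expected to give 7%, ranging from 0% to 17%.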

Compound 3, a percentage reported as inhibition, at one concentration (the size of the read-out at that concentration, not a potency): 10.3%
Estimate against measurement, compound 3: 3.3 percentage points below; the range from low to high includes it.
By their numbers in this assay, from the lowest: compounds 1, 2 and 3 (each within the scatter of the next).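

A double bond on this chain, the one new feature of the allylamino compound, brings no change beyond the scatter in this assay: vinyl in place of propyl gives a number 3.4 percentage points higher from compound 1 to compound 3 (within the scatter) and vinyl in place of ethyl gives a number 1.8 percentage points higher from compound 2 to compound 3 (within the scatter). The three chains shown therefore cannot be told apart at this position. No measurement available here offers any explanation for this.

As far as these compounds go, whether a cyclopropyl ring, or a chain ending in an amine or a carboxylic acid, would move the number beyond the scatter stays open.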